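Thiophen-2-yl in place of naphthalen-2-yl on the exocyclic carbon

This account rests on a few compounds, and the source may have more. Where it says the series, first, only, none or still open, it means among the compounds named here.

In a functional assay on DU-145 cells (Homo sapiens) for cytotoxicity, read by sulforhodamine B assay, with a stated time of 48 h (a lower number here means a stronger inhibitor, a higher number a weaker inhibitor), compound 1 `CC(=O)OC[C@H]1O[C@@H](n2cc(CN3C(=O)/C(=C\c4ccc(C)cc4)c4ccccc43)nn2)[C@H](OC(C)=O)[C@@H](OC(C)=O)[C@@H]1OC(C)=O` gives 9400 nM. Compound 2 `COc1ccc(/C=C2\C(=O)N(Cc3cn([C@@H]4O[C@H](COC(C)=O)[C@@H](OC(C)=O)[C@H](OC(C)=O)[C@H]4OC(C)=O)nn3)c3ccccc32)cc1OC` gives 24900 nM in this assay, and a 2.6-fold higher number from compound 1 to compound 2 (0.42 log units; beyond the scatter). For compound 3 `CC(=O)OC[C@H]1O[C@@H](n2cc(CN3C(=O)/C(=C\c4ccc5ccccc5c4)c4ccccc43)nn2)[C@H](OC(C)=O)[C@@H](OC(C)=O)[C@@H]1OC(C)=O` only a limit of this assay is known, > 100000 nM. Compound 3 thus stands at the weak end of the three, since an at least 10-fold higher number from compound 1 to compound 3 (1.02 log units; beyond the scatter) and an at least 4.0-fold higher number from compound 2 to compound 3 (0.60 log units; beyond the scatter); that it sits at the limit of > 100000 nM in this assay, at which 1 of the 3 values shown sits, means its exact position is open.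

Compound 4 `CC(=O)OC[C@H]1O[C@@H](n2cc(CN3C(=O)/C(=C\c4cccs4)c4ccccc43)nn2)[C@H](OC(C)=O)[C@@H](OC(C)=O)[C@@H]1OC(C)=O` differs from compound 3 by thiophen-2-yl in place of naphthalen-2-yl on a double-bonded chain carbon bound to a double-bonded ring carbon. The two measured steps bearing on this change both run into compound 3, and both gave a higher number when naphthalen-2-yl entered in place of 4-methylphenyl or 3,4-dimethoxyphenyl; the step to compound 4 removes naphthalen-2-yl again and brings in thiophen-2-yl. A lower number in this assay is therefore expected for compound 4, of modest to large size, although a start from a limit leaves the size uncertain. Compound 4 is estimated at 15000 nM, with a range of 4000 nM to 60000 nM, which is expected to mean an at least 6.6-fold lower number from compound 3 to compound 4 (0.82 log units; beyond the scatter).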

Compound 4, half-maximal inhibitory concentration: 22800 nM
The estimate for compound 4 lay 1.5-fold (0.18 log units) below the measured number; measured number inside the range.
By their numbers in this assay, from the lowest: compound 1; then compounds 4 and 2 (each within the scatter of the next). At a limit, above all of these: compound 3.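

Thiophen-2-yl in place of naphthalen-2-yl on a double-bonded chain carbon bound to a double-bonded ring carbon brings the series back to a measured number in this assay, with an at least 4.3-fold lower number from compound 3 to compound 4 (0.64 log units; beyond the scatter), so the loss seen with naphthalen-2-yl is not shared by all three other aromatic groups shown at this place. Thiophen-2-yl cannot be told apart from 3,4-dimethoxyphenyl, with a 1.1-fold lower number from compound 2 to compound 4 (0.04 log units; within the scatter), but it does not reach 4-methylphenyl, with a 2.4-fold higher number from compound 1 to compound 4 (0.38 log units; beyond the scatter). The number for compound 3 is only a limit, so the step out of it gives a bound and not a size: the limit of > 100000 nM in this assay, at which 1 of the 4 values shown sits.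

The compounds shown leave open whether the sulfur atom or the single five-membered ring of thiophen-2-yl sets this number. They also leave open how furan-2-yl, or a phenyl ring carrying an amine or a carboxylic acid, would stand at this place.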